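Ring Expansion on the Amine Side of Compound 3

This account rests on a few compounds, and the source may have more. Where it says the series, first, only, none or still open, it means among the compounds named here.

Compound 3 `FC(F)(F)c1cc(NC[C@H]2CCCN2)c2cn[nH]c2c1` gives 9580 nM in an assay for inhibition of Indoleamine 2,3-dioxygenase 1 (Homo sapiens), with stated times of 10 min and 60 min (on this read-out lower numbers stand for stronger inhibition and higher numbers for weaker inhibition), the lowest of the two numbers recorded. Its nearest neighbour, compound 2 `Oc1ccc(CNc2cc(C(F)(F)F)cc3[nH]ncc23)cc1`, gives 36700 nM in this assay, and the gap is a 3.8-fold lower number from compound 2 to compound 3 (0.58 log units; beyond the scatter). Compound 1 `Nc1cccc(CNc2cc(C(F)(F)F)cc3[nH]ncc23)c1` shows only a limit in this assay, > 100000 nM, as noted in the limit of > 100000 nM in this assay, at which 1 of the 3 values shown sits. From that limit, the steps are an at least 10-fold lower number from compound 1 to compound 3 (1.01 log units; beyond the scatter) and an at least 2.7-fold lower number from compound 1 to compound 2 (0.43 log units; beyond the scatter).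

Compound 4 `FC(F)(F)c1cc(NC[C@@H]2CCCCN2)c2cn[nH]c2c1` has not yet been measured. It differs from compound 3 in one place: piperidin-2-yl in place of pyrrolidin-2-yl on a saturated chain carbon bound to a nitrogen on an aromatic ring. Among the measured compounds shown here, neither measured step exchanges one saturated ring for another; both steps into compound 3 swap an aromatic group for the pyrrolidin-2-yl, so they show only that this saturated ring beats the two aryl groups seen, and say nothing about enlarging it to piperidin-2-yl. For the measured compounds named here, with no bearing step, no change beyond the scatter is expected, and the estimated step is a 1.0-fold higher number from compound 3 to compound 4 (0.02 log units; within the scatter). Compound 4 is therefore expected to give 10000 nM, within 3000 nM to 35000 nM.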

Compound 4, half-maximal inhibitory concentration: 18700 nM
Estimate against measurement, compound 4: 1.9-fold (0.27 log units) below; the range from low to high includes it.
By their numbers in this assay, from the lowest: compounds 3, 4 and 2 (each within the scatter of the next, the first and the last beyond it). At a limit, above all of these: compound 1.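

Among the compounds shown here, the exchange of pyrrolidin-2-yl for piperidin-2-yl, the first swap of one saturated ring for another at this place, gives in this assay a 2.0-fold higher number from compound 3 to compound 4 (0.29 log units; within the scatter), so the two rings cannot be told apart here. The piperidin-2-yl also cannot be told apart from the 4-hydroxyphenyl, with a 2.0-fold lower number from compound 2 to compound 4 (0.29 log units; within the scatter), whereas the pyrrolidin-2-yl stood clear of that group with a 3.8-fold lower number from compound 2 to compound 3 (0.58 log units; beyond the scatter). Replacing 3-aminophenyl gives an at least 5.3-fold lower number from compound 1 to compound 4 (0.72 log units; beyond the scatter), and compound 1 enters that step only as a limit of the assay, not as a number: the limit of > 100000 nM in this assay, at which 1 of the 4 values shown sits.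

The compounds shown leave open whether the nitrogen of the saturated ring matters at all, which a cyclohexyl or a morpholin-2-yl group on the same chain carbon would address. Going by these compounds, the opposite stereocentre of each ring also remains open.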